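Replacing pyrimidin-4-yl with 5-cyanothiophen-2-yl in compound 3

The source may hold more compounds than are shown below. What is called first, only, known or untested is meant among the compounds shown, and "the series" means these compounds.

In an in vitro ADME assay on microsomes from liver (Homo sapiens) for metabolic stability (a higher number here means faster removal of the compound, a lower number slower removal), compound 1 `O=C(COCc1ccccc1)N1CCN(c2ccc(F)cc2Cl)CC1` stands at 530 mL.min-1.g-1 and compound 2 `O=C(COCc1ccccn1)N1CCN(c2ccc(Cl)cc2Cl)CC1` at 94 mL.min-1.g-1 while compound 3 `O=C(COCc1ccncn1)N1CCN(c2ccc(Cl)cc2Cl)CC1` gives 17 mL.min-1.g-1 as the lowest of the three numbers. Its gaps to both others lie beyond the scatter, so compound 3 is the most slowly removed of the group.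

Compound 4 `N#Cc1ccc(COCC(=O)N2CCN(c3ccc(Cl)cc3Cl)CC2)s1` has not yet been measured. It keeps the rest of compound 3 and changes one group 5-cyanothiophen-2-yl in place of pyrimidin-4-yl on a saturated chain carbon bound to an oxygen on a saturated carbon at one place: 5-cyanothiophen-2-yl in place of pyrimidin-4-yl on a saturated chain carbon bound to an oxygen on a saturated carbon.

Within the data shown here, the one measured step at this place is a 5.5-fold lower number from compound 2 to compound 3 (0.74 log units; beyond the scatter) and it came with pyrimidin-4-yl in place of pyridin-2-yl. That modest step shows that the group here can move the number. Compound 1 differs from compound 3 in more than one place, so it offers no clean comparison. Among the measured compounds shown here, no measured compound carries 5-cyanothiophen-2-yl, which leaves this single step as the only guide to size. Compound 4 gives up the group that came with the lower number, so a rise of similar size seems likely. The step expected in this assay is a 4.7-fold higher number from compound 3 to compound 4 (0.67 log units; beyond the scatter) and it would mean faster removal. The estimate for compound 4 is 80 mL.min-1.g-1 with 25 mL.min-1.g-1 to 250 mL.min-1.g-1 as the expected range.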

Compound 4, intrinsic clearance in microsomes: 110 mL.min-1.g-1
Compound 4: the middle estimate sits 1.4-fold (0.14 log units) below what was measured; the measured number falls inside the stated range.
By their numbers in this assay, from the lowest: compound 3; then compounds 2 and 4 (each within the scatter of the next); then compound 1.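

Swapping pyrimidin-4-yl for 5-cyanothiophen-2-yl on a saturated chain carbon bound to an oxygen on a saturated carbon gives, in this assay, a 6.5-fold higher number from compound 3 to compound 4 (0.81 log units; beyond the scatter), so a second change at this place also moves the number by a clear margin. Set against pyridin-2-yl, the same group gives a 1.2-fold higher number from compound 2 to compound 4 (0.07 log units; within the scatter), which means that in this assay these two quite different groups cannot be told apart. Among the three compounds that differ only at this place, pyrimidin-4-yl therefore stands alone with the lowest number, while the other two groups sit together at a clearly higher level. Compound 1 differs in more than one place. It stays out of this comparison.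

Nothing measured on these compounds explains why pyrimidin-4-yl stands apart from the other two groups. From the compounds shown here alone, it also remains open whether the nitrile or the thiophene ring matters more in 5-cyanothiophen-2-yl, which a plain thiophen-2-yl group would help to separate, and whether a pyrazin-2-yl ring would give a number nearer that of compound 3 or that of compound 2.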